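A few compounds are considered here, and "the series" means these few. Any claim that something is new, unique, unknown or untested is made for them only; others in the source may bear on it.

Working notes on the urea series. In a functional assay on NCI-H1581 cells (Homo sapiens) for inhibition, read by MTT assay, with a stated time of 48 h, tested at 10 uM (on this read-out lower numbers stand for less inhibition and higher numbers for more inhibition at the one concentration tested (going by the name of the read-out)), compound 1 `CCc1ccc(Nc2cc(NC(=O)Nc3c(Cl)cccc3Cl)ncn2)cc1` gives 38.1%. Compound 2 `COc1cc(NC(=O)Nc2cc(Nc3ccc(C)c(F)c3)ncn2)cc(OC)c1` gives 38% and compound 3 `COc1cc(NC(=O)Nc2cc(Nc3cccc(C(C)(C)C)c3)ncn2)cc(OC)c1` gives 35.1%. Compound 1 holds the highest of the three numbers, yet both gaps to it fall within the scatter, so no order among the three can be read.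

Compound 4 `O=C(Nc1cc(Nc2ccc(F)c(Cl)c2)ncn1)Nc1c(Cl)cccc1Cl` is the unmeasured member; it differs from compound 1 by 3-chloro-4-fluorophenyl in place of 4-ethylphenyl on a nitrogen on an aromatic ring. Within the data shown here, one measured step bears on this place, the swap of the aryl on the same nitrogen: a number 2.9 percentage points lower from compound 2 to compound 3 (within the scatter). On that basis no step beyond the scatter is expected in this assay.

Compound 4 is therefore estimated at 37%, range 24% to 50%. This means an expected a number 1.1 percentage points lower from compound 1 to compound 4 (within the scatter).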

Compound 4, a percentage reported as inhibition, at one concentration (the size of the read-out at that concentration, not a potency): 67%
Compound 4: middle estimate off by 30 percentage points, on the low side; the whole stated range lies below it.
By their numbers in this assay, from the lowest: compounds 3, 2 and 1 (each within the scatter of the next); then compound 4.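

In this assay, among these compounds, the aryl group on this nitrogen proves able to move the number: the step is a number 28.9 percentage points higher from compound 1 to compound 4 (beyond the scatter), whereas the only earlier swap at this place gave a number 2.9 percentage points lower from compound 2 to compound 3 (within the scatter). The entering and leaving groups match in heavy-atom count and each has one carbon-only aromatic ring, so those counts do not separate them. No measurement available here accounts for the step. Open, going by these compounds, is whether 3-chlorophenyl or 4-fluorophenyl alone would give a similar step. Also open, on these data alone, is whether the same change would hold with another group on the urea.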